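The source may hold more compounds than are shown below. What is called first, only, known or untested is meant among the compounds shown, and "the series" means these compounds.

Measured compounds in a functional assay on MCF7 cells (Homo sapiens) for antiproliferative activity, read by MTT assay, with a stated time of 72 h; on this read-out higher numbers stand for weaker inhibition and lower numbers for stronger inhibition:
- compound 1, `CCOC(=O)c1oc2ccc(NS(=O)(=O)c3cccc(C)c3)cc2c1C`: 101000 nM
- compound 2, `CCOC(=O)c1oc2ccc(NS(=O)(=O)c3ccccc3Cl)cc2c1C`: > 200000 nM
- compound 3, `CCOC(=O)c1oc2ccc(NS(=O)(=O)c3ccc(Br)cc3)cc2c1C`: 56500 nM

Compound 2 reaches only a limit of the assay, not a number; this is the limit (the limit of > 200000 nM in this assay, at which 1 of the 3 values shown sits). Compound 3 and compound 1 sit within the scatter of each other, as the step of a 1.8-fold lower number from compound 1 to compound 3 (0.25 log units; within the scatter) shows, so the two cannot be ordered on these numbers.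

The unmeasured compound 4, `CCOC(=O)c1oc2ccc(NS(=O)(=O)c3ccccc3[N+](=O)[O-])cc2c1C`, differs from compound 3 in one place: 2-nitrophenyl in place of 4-bromophenyl on a sulfonyl sulfur. Going by the values given here, two measured steps bear on this change. The step of an at least 3.5-fold lower number from compound 2 to compound 3 (0.54 log units; beyond the scatter) compares a 2-chlorophenyl group with the 4-bromophenyl group and is beyond the scatter. The step of an at least 1.9-fold higher number from compound 1 to compound 2 (0.29 log units; that floor lies within the scatter) also moves to a 2-chlorophenyl group, ending at the limit. Both steps involving a group of the 2-substituted kind end at the limit, so compound 4 is expected to move in the same direction, towards a higher number, quite possibly to the limit again.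

For compound 4 in this assay the expected value is 150000 nM, with a range from 60000 nM to 300000 nM. This corresponds to an expected step of a 2.7-fold higher number from compound 3 to compound 4 (0.42 log units; beyond the scatter).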

Compound 4, half-maximal inhibitory concentration: 157000 nM
Estimate against measurement, compound 4: 1.0-fold (0.02 log units) below; the measured number falls inside the stated range.
By their numbers in this assay, from the lowest: compounds 3, 1 and 4 (each within the scatter of the next, the first and the last beyond it). At a limit, above all of these: compound 2.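

In this assay, going by these compounds alone, the 2-nitrophenyl group on the sulfonyl sulfur gives the first full number for a group named at the 2-position of the phenyl ring, and the loss against the 4-bromophenyl group can now be sized: a 2.8-fold higher number from compound 3 to compound 4 (0.44 log units; beyond the scatter). The same group does not separate itself from the 3-methylphenyl group, as a 1.6-fold higher number from compound 1 to compound 4 (0.19 log units; within the scatter) stays within the scatter, so the two cannot be ordered and a 2-substituted phenyl group is not shown to be worse than every other group here. Nitro and chloro on the aromatic carbon cannot be ordered either, as an at least 1.2-fold lower number from compound 2 to compound 4 (0.10 log units; that floor lies within the scatter) has a floor within the scatter, and compound 2 carries a limit of the assay rather than a number: the limit of > 200000 nM in this assay, at which 1 of the 4 values shown sits.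

No pair shown holds the same group at two places on the phenyl ring, so the effect of the group's place cannot be separated from the effect of the group itself. An amine or a carboxylic acid on that phenyl ring stands open, as does a change to the ethyl ester on the shared core.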